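Removing the ring methyl from compound 1: expected inhibition

This account rests on a few compounds, and the source may have more. Where it says the series, first, only, none or still open, it means among the compounds named here.

Measured so far:
compound 1 `C[C@@H]1N[C@H](C(=O)N2CCC[C@H]2C#N)C[C@@H]1C(=O)N1CCC1`: 94%
compound 2 `CN(C)C(=O)[C@@H]1CN[C@H](C(=O)N2CCC[C@H]2C#N)C1`: 76%
compound 3 `N#C[C@@H]1CCCN1C(=O)[C@@H]1CCCN1`: 20%

In an assay on the whole organism (plasma, strain Sprague-Dawley) for inhibition of Dipeptidyl peptidase 4 (Rattus norvegicus), with a stated time of 6 h, at a dose of 1 mg/kg by the oral route (a lower number here means less inhibition, a higher number more inhibition at the dose given (going by the name of the read-out)), compound 1 stands highest of the three: compound 2 is lower beyond the scatter, compound 3 further still. Within the data shown here, the one step between single-point changes, a number 56 percentage points lower from compound 2 to compound 3 (beyond the scatter), removes a whole dimethylcarbamoyl group and does not speak to a methyl. Compound 4 `N#C[C@@H]1CCCN1C(=O)[C@@H]1C[C@H](C(=O)N2CCC2)CN1` differs from compound 1 only as hydrogen in place of methyl on a saturated ring carbon. Among the measured compounds shown here, compound 2, which also carries no methyl on that ring, shows a value within reach of compound 1; no measured step reports loss of a methyl alone. A small downward step is expected, a number 9 percentage points lower from compound 1 to compound 4 (within the scatter), and compound 4 is estimated at 85% within 65% to 96%.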

Compound 4, a percentage reported as inhibition, in the whole organism at one dose (the size of the read-out at that dose, not a potency): 77%
Compound 4: middle estimate off by 8 percentage points, on the high side; measured number inside the range.
By their numbers in this assay, from the lowest: compound 3; then compounds 2 and 4 (each within the scatter of the next); then compound 1.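

In this assay, the methyl on the saturated ring carbon next to the ring nitrogen now has a measured step of its own, and replacing it with hydrogen gives a modest loss (a number 17 percentage points lower from compound 1 to compound 4 (beyond the scatter)). The (azetidin-1-yl)carbonyl group gives a much larger step (a number 57 percentage points higher from compound 3 to compound 4 (beyond the scatter)), while azetidin-1-yl in place of dimethylamino on the carbonyl carbon changes nothing beyond the scatter (a number 1 percentage points higher from compound 2 to compound 4 (within the scatter)). Open, as far as these compounds go, is whether ethyl or an aminomethyl group at the methyl position would hold inhibition at the level of compound 1. Nothing available explains the methyl step.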